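A few compounds are considered here, and "the series" means these few. Any claim that something is new, unique, unknown or untested is made for them only; others in the source may bear on it.

Measured so far:
compound 1 `CCCCc1ccc2[nH]c(-c3ccc(OC)cc3)c(C=O)c2c1` — 22 nM
compound 2 `CCCCc1ccc2[nH]c(-c3ccc(OC)cc3)c(/C=N/NC(=O)c3cccc(OC)c3)c2c1` — "not determined" (no result reported)

The read-out throughout is a functional assay on MCF7 cells (Homo sapiens) for antiproliferative activity, with a stated time of 5 days; on this read-out higher numbers stand for weaker inhibition and lower numbers for stronger inhibition. Compound 1, which carries a carbonyl on the shared core, gives 22 nM in this assay. Compound 2 extends that carbonyl into an acylhydrazone bearing a 3-methoxyphenyl group, but for compound 2 this assay reports only "not determined" (no result reported), so compound 2 stands on no number at all and gives no footing for a comparison.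

Compound 3 `CCCCc1ccc2[nH]c(-c3ccc(OC)cc3)c(/C=N/NC(=O)c3ccccn3)c2c1` differs from compound 2 in one place: pyridin-2-yl in place of 3-methoxyphenyl on a carbonyl carbon. Within the data shown here, no step between measured compounds is available to size this change, so no direction can be argued from the data; the expectation is a step that stays within the usual scatter or, at most, moves modestly toward weaker inhibition. Compound 3 is therefore expected to give about 100 nM in this assay, somewhere between 10 nM and 2000 nM.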

Compound 3, half-maximal inhibitory concentration: 160 nM
The estimate for compound 3 lay 1.6-fold (0.20 log units) below the measured number; measured number inside the range.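

Among these compounds, compound 2 has no number in this assay and so no step to compound 3 can be read from this pair. The compounds shown leave open how replacing 3-methoxyphenyl with pyridin-2-yl on the carbonyl carbon shifts inhibition. No supporting evidence bears on this result.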